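Hexylamino in place of benzyloxy: a small step expected

A few compounds are considered here, and "the series" means these few. Any claim that something is new, unique, unknown or untested is made for them only; others in the source may bear on it.

In a functional assay on WI-38 VA13 cells (Homo sapiens) for cytotoxicity (on this read-out higher numbers stand for an effect only at larger amounts of compound and lower numbers for an effect already at smaller amounts), compound 1 (`O=C(Nc1ccc2nc(NC(=O)C3CCCCC3)sc2c1)c1c(Cl)cccc1Cl`) gives 0.015 ug/mL while compound 2 (`CCCOC(=O)Nc1nc2ccc(NC(=O)c3c(Cl)cccc3Cl)cc2s1`) gives 0.0025 ug/mL and compound 3 (`O=C(Nc1nc2ccc(NC(=O)c3c(Cl)cccc3Cl)cc2s1)OCc1ccccc1`) gives 0.018 ug/mL on the same read-out. Compound 3 and compound 1 lie within the scatter of each other at the high end of the three numbers. The gap to the remaining member is a 7.2-fold higher number from compound 2 to compound 3 (0.86 log units; beyond the scatter) and lies beyond the scatter.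

For the measured compounds named here, compound 4 (`CCCCCCNC(=O)Nc1nc2ccc(NC(=O)c3c(Cl)cccc3Cl)cc2s1`) differs from compound 3 by one change on a carbonyl carbon, hexylamino in place of benzyloxy (hexylamino in place of benzyloxy on a carbonyl carbon) and this swap has no measured precedent. Going by the values given here, no measured step places an amino group on this carbon, so the earlier steps bound the size only. Changes at this carbon run from a 1.2-fold higher number from compound 1 to compound 3 (0.08 log units; within the scatter) which stays within the scatter, to a 6.0-fold lower number from compound 1 to compound 2 (0.78 log units; beyond the scatter) which is modest and beyond it. Hexylamino has no ring, as with the propoxy of compound 2 at 0.0025 ug/mL so a slight lean towards lower numbers seems fair.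

No step beyond the scatter is expected, and the estimated change is a 1.8-fold lower number from compound 3 to compound 4 (0.26 log units; within the scatter) in this assay on this evidence. The estimate for compound 4 is 0.01 ug/mL with an expected range from 0.003 ug/mL to 0.04 ug/mL on present evidence.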

Compound 4, half-maximal effective concentration: 0.29 ug/mL
Compound 4: the middle estimate sits 29-fold (1.46 log units) below what was measured; the whole stated range lies below it.
By their numbers in this assay, from the lowest: compound 2; then compounds 1 and 3 (each within the scatter of the next); then compound 4.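

In this assay, for the compounds shown here, hexylamino on this carbonyl carbon gives the first large step at the position, with a 16-fold higher number from compound 3 to compound 4 (1.21 log units; beyond the scatter) and a 19-fold higher number from compound 1 to compound 4 (1.29 log units; beyond the scatter), and the widest gap of all is a 120-fold higher number from compound 2 to compound 4 (2.06 log units; beyond the scatter) and places compound 4 highest of the four. The earlier changes here stayed far smaller, the largest being a 7.2-fold higher number from compound 2 to compound 3 (0.86 log units; beyond the scatter), so the position proves much less forgiving of this swap than those compounds suggested, and losing the ring cannot by itself go with the higher number, as propoxy also has no ring and compound 2 has the lowest number of the series. Nothing available here explains why hexylamino behaves so differently from the other groups.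

From the compounds shown here alone, what remains open is whether the rise goes with the amino link or with the length of the hexyl chain, and a propylamino or a hexyloxy group on this carbonyl carbon would separate the two. Going by these compounds, it is also open whether the hydrogen on the entering nitrogen matters, which a dialkylamino group such as N-methylhexylamino would address.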